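Amide for acid at the chain end of compound 3

A few compounds are considered here, and "the series" means these few. Any claim that something is new, unique, unknown or untested is made for them only; others in the source may bear on it.

Measured compounds:
compound 1, `O=C(CN(c1nc(Cl)nc2[nH]cnc12)C1CC1)N[C@@H](CC(=O)OCc1ccccc1)C(=O)OCc1ccccc1`: 22.4%
compound 2, `O=C(CN(c1nc(Cl)nc2[nH]cnc12)C1CC1)N[C@@H](CCC(=O)OCc1ccccc1)C(=O)OCc1ccccc1`: 53.7%
compound 3, `O=C(O)CC[C@H](NC(=O)CN(c1nc(Cl)nc2[nH]cnc12)C1CC1)C(=O)O`: 33.3%

In a functional assay on the whole organism (Tail, strain ICR) with Mus musculus as the target, in the tail flick test, with a stated time of 60 min, at a dose of 25 umol/kg by the oral route (a lower number here means a weaker effect, a higher number a stronger effect of the compound at the dose given), compound 3 holds the second highest of the three numbers: compound 1 sits lower, compound 2 sits higher, and both gaps lie beyond the scatter. Going by the values given here, the only step between two compounds that differ in one place, a number 31.3 percentage points higher from compound 1 to compound 2 (beyond the scatter), concerns the length of the chain carrying a benzyloxycarbonyl group, not the end group of the chain itself, so it does not bear on the change at hand. Compound 4, `NC(=O)CC[C@H](NC(=O)CN(c1nc(Cl)nc2[nH]cnc12)C1CC1)C(=O)O`, differs from compound 3 by amino in place of hydroxy on a carbonyl carbon. Among the compounds with values here, no measured pair shows this kind of change, so there is no measured step to anchor an expectation; what remains is that compound 3 itself sits in the middle of the range seen. Compound 4 is therefore expected to stay close to compound 3, with a step of a number 0.3 percentage points lower from compound 3 to compound 4 (within the scatter) that need not exceed the scatter. The estimate for compound 4 is 33%, within 15% to 55%.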

Compound 4, a percentage reported as activity, at one dose (the size of the read-out at that dose, not a potency): 38.4%
Estimate against measurement, compound 4: 5.4 percentage points below; the range from low to high includes it.
By their numbers in this assay, from the lowest: compound 1; then compounds 3 and 4 (each within the scatter of the next); then compound 2.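

In this assay, amino in place of hydroxy on a carbonyl carbon gives a number 5.1 percentage points higher from compound 3 to compound 4 (within the scatter) and is the only reading of a change to this group among the compounds shown. In this pair, the 2-carboxyethyl and 2-carbamoylethyl forms therefore cannot be told apart at the dose given, so this one exchange of atoms leaves the read-out within its usual scatter. No measurement at hand offers an explanation for this result.

The compounds shown leave open whether a larger group on this carbonyl carbon, such as a methylamino group, a dimethylamino group or a methoxy group, would also stay within the scatter. They also leave open whether a longer chain, such as 3-carbamoylpropyl, would keep the read-out of the shorter 2-carbamoylethyl chain.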